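Replacing a hydrogen on oxygen in compound 1

This account rests on a few compounds, and the source may have more. Where it says the series, first, only, none or still open, it means among the compounds named here.

Within the data shown here, compound 1 (`C=C1C(=O)[C@@]23C(=O)OC[C@]4(C(=O)CCC(C)(C)[C@H]4C=O)[C@@H]2CC[C@@H]1[C@H]3O`) is the only compound with a measured number so far. In a functional assay on Bel-7402 cells (Homo sapiens) for antiproliferative activity, read by MTT assay, with a stated time of 72 h (on this read-out lower numbers stand for stronger inhibition and higher numbers for weaker inhibition), compound 1 gives 4670 nM as its result. For compound 2 (`C=C1C(=O)[C@@]23C(=O)OC[C@]4([C@@H](OC(C)=O)CCC(C)(C)[C@H]4C=O)[C@@H]2CC[C@@H]1[C@H]3O`) this assay returns > 50000 nM as a limit and not a number.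

Compound 3 (`C=C1C(=O)[C@@]23C(=O)OC[C@]4(C(=O)CCC(C)(C)[C@H]4C=O)[C@@H]2CC[C@@H]1[C@H]3OC(=O)CCCCC1CCSS1`) keeps the core of compound 1 and differs from it in one place: a group of 11 heavy atoms (8 carbon, 1 oxygen, 2 sulfur; one five-membered non-aromatic ring with 2 hetero atoms) in place of a hydrogen atom, on an oxygen on a saturated carbon is the whole change. The entering group brings one five-membered non-aromatic ring with 2 hetero atoms.

Among the measured compounds shown here, no measured pair isolates this change, so its size in this assay has to be judged without precedent. A modest step towards stronger inhibition is expected, of about the size of the scatter, though the opposite direction cannot be ruled out. The value of compound 1 at 4670 nM remains the only anchor for this expectation. The estimated change is a 1.9-fold lower number from compound 1 to compound 3 (0.27 log units; within the scatter) on this reading. Compound 3 is expected at 2500 nM with a range from 700 nM to 9000 nM as the estimate.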

Compound 3, half-maximal inhibitory concentration: 2560 nM
Compound 3: the middle estimate sits 1.0-fold (0.01 log units) below what was measured; the range from low to high includes it.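

Placing the group of 11 heavy atoms on an oxygen on a saturated carbon, in place of a hydrogen atom, gives in this assay a 1.8-fold lower number from compound 1 to compound 3 (0.26 log units; within the scatter). Among these compounds, this is the first reading at this position, and it shows that the hydrogen on this oxygen can be replaced by a group of this size, with its one five-membered non-aromatic ring with 2 hetero atoms, without a change beyond the usual scatter. The data shown offer no measured basis for explaining this outcome.

Among the compounds shown here, the single substituted compound cannot show whether the ring with its two sulfur atoms contributes anything of its own or whether the chain carrying it would serve as well, so a plain octanoyl chain on the same oxygen, without the ring, would be the informative comparison. Going by these compounds, it also remains open whether this position can give a step beyond the scatter in either direction, for instance with an amine or a carboxylic acid at the end of the chain in place of the ring.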